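Chloro for Fluoro on a Pyrazine Amide Core

A few compounds are considered here, and "the series" means these few. Any claim that something is new, unique, unknown or untested is made for them only; others in the source may bear on it.

Compound 3, `O=C(Nc1cc(F)cc2cccnc12)c1cnccn1`, is tested in a functional assay on BXPC-3 cells (Homo sapiens) for inhibition, read by MTT assay, with a stated time of 72 h; a higher number here means a weaker inhibitor, a lower number a stronger inhibitor. There compound 3 gives > 10000 nM, which is a limit of the assay rather than a number. Compound 1, `Cc1cnc(C(=O)Nc2cc(F)cc3cccnc23)cn1`, gives > 10000 nM in this assay, again a limit. Compound 2, `Cc1cnc(C(=O)Nc2cc(Cl)cc3cccnc23)cn1`, reaches 5200 nM in this assay, a real number. These three share one core; compound 2 differs from compound 1 only by chloro in place of fluoro, and that gave an at least 1.9-fold lower number from compound 1 to compound 2 (0.28 log units; that floor lies within the scatter). Compound 3 differs from compound 1 by hydrogen in place of methyl, a step that the two limits leave unreadable, a step that the two limits leave unreadable from compound 1 to compound 3, since the limit of > 10000 nM in this assay, at which 2 of the 3 values shown sit, hides how far apart the two actually lie.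

Compound 4, `O=C(Nc1cc(Cl)cc2cccnc12)c1cnccn1`, is not yet measured. It differs from compound 3 as chloro in place of fluoro on an aromatic carbon, the same swap that led from compound 1 to compound 2. On that single precedent a modest move toward a lower number is expected for compound 4, of about an at least 1.4-fold lower number from compound 3 to compound 4 (0.15 log units; that floor lies within the scatter), although the floor of that earlier step sits within the scatter, so no change at all would not surprise. Compound 4 is therefore estimated at 7000 nM in this assay, within 3000 nM to 20000 nM, with a fair chance that only a limit is reported.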

Compound 4, half-maximal inhibitory concentration: > 10000 nM
Compound 4: only a limit was reported; the forecaster's own chance of this, stated with the estimate: 40%; middle value at least 1.4-fold (0.15 log units) away from the limit.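

On the core without the methyl, chloro on this aromatic carbon, para to a fused ring, does not bring a real number: compound 4 gives > 10000 nM in this assay, which is a limit of the assay. The chloro compounds now form a pair that differs only by hydrogen in place of methyl, and this gives an at least 1.9-fold higher number from compound 2 to compound 4 (0.28 log units; that floor lies within the scatter), so this floor alone does not show that the methyl matters, and compound 2 remains the only one of the four with a real number. The steps that join two limits, including chloro in place of fluoro on the core without the methyl, cannot be read, and most of this small set sits at that same ceiling: the limit of > 10000 nM in this assay, at which 3 of the 4 values shown sit.

Going by these compounds, with a real number for compound 2 alone, it stays open whether the chloro and the methyl work together or whether each would shift the value separately. The compounds shown also leave open how a bromo, a methoxy or an amine on this carbon, or an ethyl in place of the methyl, would read in this assay.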